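This account rests on a few compounds, and the source may have more. Where it says the series, first, only, none or still open, it means among the compounds named here.

Measured so far in an assay on MDA-MB-231 cells for binding affinity to C-X-C chemokine receptor type 4 (Homo sapiens), read by immunofluorescence and microscopy, with stated times of 10 min and 30 min; on this read-out higher numbers stand for an effect only at larger amounts of compound and lower numbers for an effect already at smaller amounts:
compound 1 `COc1ccc(C(=O)NCc2ccc(CNS(=O)(=O)c3ccc(C)cc3)cc2)cc1` gives 100 nM
compound 2 `Cc1ccc(C(=O)NCc2ccc(CNS(=O)(=O)c3ccc(C)cc3)cc2)cc1` gives 1000 nM
compound 3 `O=C(NCc1ccc(CNS(=O)(=O)c2ccccc2)cc1)c1ccncc1` gives 10 nM

Compound 2 has the highest number of these three, with compound 1 giving a lower number and compound 3 a lower number still. The move to compound 4 `COc1ccccc1C(=O)NCc1ccc(CNS(=O)(=O)c2ccc(C)cc2)cc1` changes one part: 2-methoxyphenyl in place of 4-methylphenyl on a carbonyl carbon. Within the data shown here, the only measured step that speaks to this is the exchange of methoxy for methyl, a 10-fold higher number from compound 1 to compound 2 (1.00 log units; beyond the scatter). Running that exchange backwards, a methoxy group in place of methyl should bring the number down by a comparable amount, although the methoxy here sits in a different position, so the size is uncertain. A step in this assay of roughly a 6.7-fold lower number from compound 2 to compound 4 (0.82 log units; beyond the scatter) is therefore expected, towards lower numbers. Compound 4 is estimated at 150 nM, between 30 nM and 1000 nM.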

Compound 4, effective concentration (reported as EC, without a stated level of effect): 100 nM
Beside the measured number, compound 4's estimate is 1.5-fold (0.18 log units) above it; measured number inside the range.
By their numbers in this assay, from the lowest: compound 3; then compounds 1 and 4 (each within the scatter of the next); then compound 2.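

In this assay, 2-methoxyphenyl in place of 4-methylphenyl on a carbonyl carbon gives a 10-fold lower number from compound 2 to compound 4 (1.00 log units; beyond the scatter), so a lower number than with 4-methylphenyl is not tied to 4-methoxyphenyl alone. Exchanging 4-methoxyphenyl for 2-methoxyphenyl gives no change at the digits printed from compound 1 to compound 4 (within the scatter), so this assay does not separate these two methoxyphenyl groups. No supporting data are available to explain either result. Still open, going by these compounds, is whether the same holds for other groups on this ring, such as an amine or a carboxylic acid.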